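The compounds below may be only part of what the source reports. "The series", "measured", "known", "first", "only" and "open" are said of these compounds alone.

In a functional assay on MCF7 cells (Homo sapiens) for cytotoxicity, read by MTT assay, with a stated time of 72 h (a higher number here means a weaker inhibitor, a lower number a stronger inhibitor), compound 1 `O=C1c2c[n+]([O-])c3ccccc3c2C(=O)c2c1c1ccccc1n2CCCCn1ccnc1` gives 130 nM and compound 2 `O=C1c2c[n+]([O-])c3ccccc3c2C(=O)c2c1c1ccccc1n2CCCCN1CCCCC1` gives 150 nM. Compound 3 `CCCN1CCN(CCCCn2c3c(c4ccccc42)C(=O)c2c[n+]([O-])c4ccccc4c2C3=O)CC1` gives 1280 nM, the highest number of the three and the weakest inhibitor in this small set.

Compound 4 `CN1CCN(CCCCCCn2c3c(c4ccccc42)C(=O)c2c[n+]([O-])c4ccccc4c2C3=O)CC1` is reached from compound 3 by 2-(4-methylpiperazin-1-yl)ethyl in place of 4-propylpiperazin-1-yl on a saturated chain carbon, four bonds along the chain from an aromatic nitrogen. The two have the same atoms, joined differently.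

For the measured compounds named here, two measured steps bear on this change: a 9.8-fold higher number from compound 1 to compound 3 (0.99 log units; beyond the scatter) and an 8.5-fold higher number from compound 2 to compound 3 (0.93 log units; beyond the scatter). Both are modest and beyond the scatter, and both bring in 4-propylpiperazin-1-yl. Neither keeps a piperazine group while altering the chain, so the data do not separate a change in chain from a change from propyl to methyl. Compound 4 retains a piperazine group, so a step as large as those two is not expected in this assay. As far as these compounds go, the direction remains open, with a slight lean towards a lower number.

The expected step is a 1.6-fold lower number from compound 3 to compound 4 (0.20 log units; within the scatter). The estimated value for compound 4 is 800 nM, with an expected range of 250 nM to 2500 nM.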

Compound 4, half-maximal inhibitory concentration: 400 nM
Compound 4: middle estimate off by 2.0-fold (0.30 log units), on the high side, within the range that was stated.
By their numbers in this assay, from the lowest: compounds 1 and 2 (each within the scatter of the next); then compound 4; then compound 3.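

In this assay, the step of a 3.2-fold lower number from compound 3 to compound 4 (0.51 log units; beyond the scatter) shows that the high number of compound 3 does not follow from a piperazine group at this place alone, as the same atoms arranged as 2-(4-methylpiperazin-1-yl)ethyl give a clearly lower number than 4-propylpiperazin-1-yl. The recovery is only partial, with a 2.7-fold higher number from compound 2 to compound 4 (0.43 log units; beyond the scatter) and a 3.1-fold higher number from compound 1 to compound 4 (0.49 log units; beyond the scatter), so neither piperazine arrangement reaches piperidin-1-yl or 1H-imidazol-1-yl on this evidence. No accompanying measurement accounts for these steps.

The change from compound 3 to compound 4 alters chain length and the alkyl group on the piperazine together, and the two contributions remain unseparated. A 4-(4-methylpiperazin-1-yl)butyl group and a 6-(4-propylpiperazin-1-yl)hexyl group would each vary one of them alone.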